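Nitro for Chloro on a Shared Isatin-Type Core

The compounds below may be only part of what the source reports. "The series", "measured", "known", "first", "only" and "open" are said of these compounds alone.

Measured compounds and their values in a functional assay on COLO 205 cells (Homo sapiens) for inhibition, read by sulforhodamine B assay, with a stated time of 48 h, tested at 50 uM; a lower number here means less inhibition of growth, a higher number more inhibition of growth at the concentration tested:
compound 1 `O=C1C(=O)N(CCCCn2cc(COc3cc(=O)oc4ccccc34)nn2)c2ccc([N+](=O)[O-])cc21` gives 45%;
compound 2 `O=C1C(=O)N(CCCCn2cc(COc3cc(=O)oc4ccccc34)nn2)c2ccc(Cl)cc21` gives 60%;
compound 3 `O=C1C(=O)N(CCCn2cc(COc3cc(=O)oc4ccccc34)nn2)c2ccc(Cl)cc21` gives 67%.

Compounds 2 and 1 share a core and differ by one change, (nitro in place of chloro on an aromatic carbon). In this assay that change gave a number 15 percentage points lower from compound 2 to compound 1 (beyond the scatter).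

Compound 3 carries the same chloro group on a different core; the difference between the two cores is not broken down here. In this assay compound 3 gives 67%, and compound 2 gives 60%, two numbers that lie within the usual scatter of each other. Compound 1, at 45%, sits further from compound 3, and that gap is beyond the scatter.

Compound 4 `O=C1C(=O)N(CCCn2cc(COc3cc(=O)oc4ccccc34)nn2)c2ccc([N+](=O)[O-])cc21` has not yet been measured. Going by the values given here, it differs from compound 3 by nitro in place of chloro on an aromatic carbon, the same change as the one from compound 2 to compound 1, made at the same place on the ring. Among the compounds with values here, for compound 4 a step of about a number 15 percentage points lower from compound 3 to compound 4 (beyond the scatter) in this assay is expected, resting on the single earlier step of a number 15 percentage points lower from compound 2 to compound 1 (beyond the scatter) and on compound 3's own value 67%. Within the data shown here, only one such step has been seen. The estimate is uncertain. For compound 4 the expected value in this assay is 52%, with a plausible range from 40% to 64%.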

Compound 4, percent growth inhibition at one concentration: 52%
The estimate for compound 4 equals the measured number at the digits printed, and the stated range covers the measured number.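

In this assay the replacement of chloro by nitro on the aromatic carbon gave a number 15 percentage points lower from compound 3 to compound 4 (beyond the scatter) and so repeated on a second core what had been seen on the first, with the two steps in agreement: the same change on two cores in this assay, a number 15 percentage points lower (beyond the scatter) from compound 2 to compound 1 and a number 15 percentage points lower (beyond the scatter) from compound 3 to compound 4, 0 percentage points apart, within the scatter of two such steps. Within this small series, the change therefore carried over from one core to the other with its direction and size intact, and the step seen on the core of compound 2 served as a fair guide to the step on the core of compound 3. Going by these compounds alone, this does not show that the change would transfer to cores beyond these two, since only two matched pairs support it, each read at a single concentration in one cell line, and it gives no explanation for why growth inhibition fell with nitro in place of chloro.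

The compounds shown leave open how other groups at this aromatic carbon, such as an amine, a carboxylic acid or a methoxy group, would compare with chloro and nitro. Within the data shown here, they also leave open whether the same step would appear on a core with a longer chain than the one in compound 1.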